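The compounds below may be only part of what the source reports. "The series", "measured", "known", "first", "only" and "open" are said of these compounds alone.

Series notes, allosteric modulation of the glutamate receptor.

Compound 2 `CCCC(=O)c1ccc(OCCCCOc2cc(C(=O)O)ccc2OC)c(C)c1O` holds the highest number among the three measured compounds in an assay on HEK293 cells for positive allosteric modulation of metabotropic glutamate receptor 3 (Rattus norvegicus), read by thallium flux, with a stated time of 2.5 min (on this read-out higher numbers stand for larger maximal responses and lower numbers for smaller maximal responses), giving 64.2%. Compound 1 `Cc1c(OCCCCOc2ccccc2C(=O)O)ccc(C(=O)CC2CCCC2)c1O` gives 32.9% in this assay, and compound 3 `Cc1c(OCCCCOc2ccc(C(=O)O)cc2F)ccc(C(=O)CC2CCCC2)c1O` gives 31.2%; both of these differ from compound 2 at the carbonyl substituent and at the aryl on the ether oxygen, so their lower numbers cannot be attributed to either place alone. For the measured compounds named here, the only single-site step measured, a number 1.7 percentage points lower from compound 1 to compound 3 (within the scatter), concerns the aryl on the ether oxygen and does not touch the chain on the carbonyl.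

Compound 4 `COc1ccc(C(=O)O)cc1OCCCCOc1ccc(C(C)=O)c(O)c1C` is not yet measured in this assay. Relative to compound 2 the change is hydrogen in place of ethyl on a saturated chain carbon bound to a carbonyl carbon. Going by the values given here, no measured step bears on this position; the step between compound 1 and compound 3 lies elsewhere and was within the scatter. In the absence of a relevant comparison, compound 4 is expected to stay near compound 2, with a modest downward lean estimated as a number 9.2 percentage points lower from compound 2 to compound 4 (within the scatter). The estimate for compound 4 in this assay is therefore 55%, with a range from 35% to 75%.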

Compound 4, largest response reached (reported as percent of maximum), in percent of the reference or control that the assay uses: 34.8%
Compound 4: middle estimate off by 20.2 percentage points, on the high side, outside the stated range (below it).
By their numbers in this assay, from the lowest: compounds 3, 1 and 4 (each within the scatter of the next); then compound 2.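

In this assay, the chain on the carbonyl proves to be a sensitive place: hydrogen in place of ethyl on a saturated chain carbon bound to a carbonyl carbon, which turns propylcarbonyl into acetyl, gives a number 29.4 percentage points lower from compound 2 to compound 4 (beyond the scatter). For the compounds shown here, this is the first single-site step at this position, and unlike the earlier step on the aryl on the ether oxygen, it lies beyond the scatter, so the propyl of compound 2 cannot be treated as an interchangeable part of the core. No measurement at hand accounts for the size of this step.

Going by these compounds, with only propyl and methyl read against each other on this aryl pattern, it remains open how the response runs through an intermediate ethyl chain, and whether a longer chain such as pentyl or a branched one such as isopropyl would hold or exceed the number of compound 2. On these data alone, it is also open whether shortening the chain costs as much when the aryl on the ether oxygen is a different one.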